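Replacing a cyclic amide ring with a methoxycyclohexyl amine

The source may report more compounds than this note shows. Statements on the series, on what has been measured and on what is new or still open speak of the compounds shown alone.

Compound 1 `CCN(CC)S(=O)(=O)c1ccc(S(=O)(=O)N2CCC[C@@H](C(=O)N3CCC(F)(F)CC3)C2)cc1`: 120 nM
Compound 2 `CCN(CC)S(=O)(=O)c1ccc(S(=O)(=O)N2CCC[C@@H](C(=O)N3CCC(O)CC3)C2)cc1`: 4710 nM
Compound 3 `CCN(CC)S(=O)(=O)c1ccc(S(=O)(=O)N2CCC[C@@H](C(=O)N3CC[C@@H](OC)C3)C2)cc1`: 11500 nM

In a functional assay on BXPC-3 cells (Homo sapiens) for inhibition, read by MTT assay, with a stated time of 7 days (a lower number here means a stronger inhibitor, a higher number a weaker inhibitor), compound 3 gives the highest number of the three, that is the weakest inhibition. Compound 4 `CCN(CC)S(=O)(=O)c1ccc(S(=O)(=O)N2CCC[C@@H](C(=O)N[C@H]3CC[C@@H](OC)CC3)C2)cc1` differs from it by (4-methoxycyclohexyl)amino in place of 3-methoxypyrrolidin-1-yl on a carbonyl carbon. Going by the values given here, no measured step covers this change; the steps seen, a 39-fold higher number from compound 1 to compound 2 (1.59 log units; beyond the scatter) and a 96-fold higher number from compound 1 to compound 3 (1.98 log units; beyond the scatter), concern the fluorinated ring, and a 2.4-fold higher number from compound 2 to compound 3 (0.39 log units; beyond the scatter) shows that the hydroxy six-membered ring beats the methoxy five-membered ring only modestly. A six-membered ring returns in compound 4, so a modest move toward compound 2 is expected, and compound 4 is estimated at 6000 nM (range 1500 nM to 25000 nM), an expected step of a 1.9-fold lower number from compound 3 to compound 4 (0.28 log units; within the scatter).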

Compound 4, half-maximal inhibitory concentration: 2150 nM
Compound 4: the middle estimate sits 2.8-fold (0.45 log units) above what was measured; the range from low to high includes it.
By their numbers in this assay, from the lowest: compound 1; then compound 4; then compound 2; then compound 3.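

In this assay, the (4-methoxycyclohexyl)amino group gives a stronger inhibitor than 3-methoxypyrrolidin-1-yl, a 5.3-fold lower number from compound 3 to compound 4 (0.73 log units; beyond the scatter), and also than 4-hydroxypiperidin-1-yl, a 2.2-fold lower number from compound 2 to compound 4 (0.34 log units; beyond the scatter). So on this carbonyl carbon, a ring of carbon only, attached through a nitrogen that keeps the amide hydrogen, does better than these two rings attached through their own ring nitrogen. Even so, it does not match 4,4-difluoropiperidin-1-yl, an 18-fold higher number from compound 1 to compound 4 (1.25 log units; beyond the scatter).

Still open, as far as these compounds go, is how a (4,4-difluorocyclohexyl)amino group would compare on this carbonyl carbon. Nothing available gives a reason for any of these differences.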